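Phenyl to 2,4-difluorophenyl: compound 2 to compound 4

A few compounds are considered here, and "the series" means these few. Any claim that something is new, unique, unknown or untested is made for them only; others in the source may bear on it.

Measured in an ADME assay on MT4 cells (Homo sapiens) for cytotoxicity, read by MTT assay, with a stated time of 96 h; on this read-out lower numbers stand for higher toxicity in this test and higher numbers for lower toxicity in this test:
- compound 1 `Fc1ccc(F)c(/N=N/c2ccc(NC[C@@H]3CCCN4CCCC[C@H]34)c3c2CCCC3)c1`: 40000 nM
- compound 2 `c1ccc(/N=N/c2ccc(NC[C@@H]3CCCN4CCCC[C@H]34)c3c2CCCC3)cc1`: 100000 nM
- compound 3 `CN(Cc1ccccc1)/N=N/c1ccccc1`: >= 100000 nM (a limit)

Compound 2, at 100000 nM, holds the higher of the two actual numbers in this set, and its nearest neighbour is compound 1. Compound 3 gives >= 100000 nM, which is a limit and not a number; this is the limit of >= 100000 nM in this assay, at which 1 of the 3 values shown sits.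

The next change leads to compound 4 `Fc1ccc(/N=N/c2ccc(NC[C@@H]3CCCN4CCCC[C@H]34)c3c2CCCC3)c(F)c1`, with 2,4-difluorophenyl in place of phenyl on a double-bonded nitrogen.

Going by the values given here, one measured step bears on this change, and it is modest: a 2.5-fold higher number from compound 1 to compound 2 (0.40 log units; beyond the scatter). That step puts phenyl in place of 2,5-difluorophenyl on a double-bonded nitrogen, so it runs opposite in direction to the change now considered. Among the compounds with values here, it is a single pair, and the fluorine pattern in compound 4 is not the one in compound 1. A step of similar modest size towards a lower number is therefore expected in this assay. The expected change is a 2.2-fold lower number from compound 2 to compound 4 (0.35 log units; beyond the scatter). For compound 4 the estimated value is 45000 nM, with an expected range of 20000 nM to 100000 nM.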

Compound 4, half-maximal cytotoxic concentration: 51000 nM
Beside the measured number, compound 4's estimate is 1.1-fold (0.05 log units) below it; low and high end bracket the measured number.
By their numbers in this assay, from the lowest: compounds 1, 4 and 2 (each within the scatter of the next, the first and the last beyond it).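

In this assay, replacing phenyl with 2,4-difluorophenyl on a double-bonded nitrogen gives a 2.0-fold lower number from compound 2 to compound 4 (0.29 log units; within the scatter), so this change alone cannot be told from the scatter, whereas the earlier pair, compound 1 and compound 2, gave a step beyond it. Going by these compounds alone, the new compound also allows the first comparison of two fluorine patterns at this position, and the result is a 1.3-fold higher number from compound 1 to compound 4 (0.11 log units; within the scatter): in this read-out, 2,4-difluorophenyl and 2,5-difluorophenyl cannot be separated. Compound 3 still carries a limit and not a number, and so adds no step to these comparisons: the limit of >= 100000 nM in this assay, at which 1 of the 4 values shown sits.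

Open, as far as these compounds go, is whether a single fluorine, a chlorine, a methoxy group or a pyridine ring in place of phenyl on the double-bonded nitrogen would give a step clearly beyond the scatter, and whether the gap between compound 1 and compound 2 would hold up across such further groups. Within the data shown here, also open is whether an amine or a carboxylic acid on that aromatic ring would shift the number in this test at all, since the series so far varies fluorine only.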